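The source may report more compounds than this note shows. Statements on the series, on what has been measured and on what is new or still open speak of the compounds shown alone.

The measured compounds and their values in an assay on isolated protein for inhibition of legumain (Homo sapiens), with stated times of 2 min and 60 min; on this read-out lower numbers stand for stronger inhibition and higher numbers for weaker inhibition:

Compound 1, `CS(=O)(=O)N(CC(=O)N[C@H](C#N)CC(N)=O)Cc1ccc(-c2cccc(F)c2F)cc1`: compound 1 gives > 10000 nM, which is a limit of the assay and not a number.
Compound 2, `C[C@@H](C(=O)N[C@H](C#N)CC(N)=O)N(Cc1ccc(-c2ccc(F)c(F)c2)cc1)S(C)(=O)=O`: compound 2 gives 252 nM.
Compound 3, `C[C@H](C(=O)N[C@H](C#N)CC(N)=O)N(Cc1ccc(-c2ccc(F)c(F)c2)cc1)S(C)(=O)=O`: compound 3 gives 6300 nM.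

Compound 3 therefore stands at the highest of the two numbers shown in this assay. Going by the values given here, the only counted step among the measured compounds is a 25-fold higher number from compound 2 to compound 3 (1.40 log units; beyond the scatter), and it rests on (the fact that compounds 2 and 3 differ only in the configuration as drawn); the two compounds do not differ in any group.

Compound 4, `C[C@H](C(=O)N[C@H](C#N)CC(N)=O)N(Cc1ccc(-c2ccc(F)cc2)cc1)S(C)(=O)=O`, has not been measured. It differs from compound 3 by hydrogen in place of fluoro on an aromatic carbon. No measured step involves a change of a fluoro group, so nothing among the numbers shown bears on this change directly, and the change is small against the shared core. The expectation is therefore for a step of no change at the digits printed from compound 3 to compound 4 (within the scatter), that is, none beyond the scatter. Compound 4 is expected to give about 6300 nM, within a range from 2000 nM to 20000 nM.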

Compound 4, half-maximal inhibitory concentration: > 10000 nM
Compound 4 was reported as a limit (the forecaster's own chance of this, stated with the estimate: 25%); at least 1.5-fold (0.20 log units) between middle value and limit.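

Going by these compounds alone, putting hydrogen in place of fluoro on this aromatic carbon, which turns 3,4-difluorophenyl into 4-fluorophenyl, gives an at least 1.5-fold higher number from compound 3 to compound 4 (0.20 log units; that floor lies within the scatter), the first step at this position. In this assay, from the compounds shown here alone, compound 4 gives > 10000 nM, which is a limit and not a number, so the true size of the step stays unknown and its floor alone does not show that this fluoro group matters. The reading of this change is bounded by the range of the assay: the limit of > 10000 nM in this assay, at which 2 of the 4 values shown sit.

The compounds shown leave open how the same change reads in the configuration of compound 2, whose 252 nM is a number that leaves room for a step to be read. They also leave open how a chloro group, a methoxy group or an amine on this aromatic carbon would compare with fluoro and hydrogen.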